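The source may report more compounds than this note shows. Statements on the series, on what has been measured and on what is new or still open speak of the compounds shown alone.

Two triazenes have so far been measured in a functional assay on L1210 cells (Mus musculus) for antiproliferative activity; a lower number here means a less potent compound, a higher number a more potent compound, by a factor of ten per unit of this negative logarithm. Compound 1 `COc1ccc(C(N)=O)cc1/N=N/N(C)C` carries its triazene, with two methyls on the terminal nitrogen, on a core that also bears a methoxy group and a carboxamide; in this assay compound 1 gives 3.95. Compound 2 `CN(CCO)/N=N/c1n[nH]cc1C(N)=O` places the triazene on a different core, again bearing a carboxamide, and carries a 2-hydroxyethyl and a methyl on the terminal nitrogen; in this assay compound 2 gives 3.1. Of the two numbers compound 2 stands lowest, and its gap to compound 1 lies beyond the usual scatter. The two compounds differ in more than one place, so no single step can be read between them.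

Compound 3 `CCCCN(C)/N=N/c1n[nH]cc1C(N)=O` keeps the core of compound 2 and alters only the chain on the terminal nitrogen: ethyl in place of hydroxy on a saturated chain carbon, two bonds along the chain from an amine nitrogen. Within the data shown here, no step of this kind is known among the measured compounds, so what follows is an expectation only. A modest gain, a number 0.30 log units higher from compound 2 to compound 3 (within the scatter), is expected, but one that may not clear the scatter. Compound 3 is accordingly estimated at 3.4, with a range from 2.8 to 4.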

Compound 3, logarithm of the reciprocal of the active concentration, log(1/C): 3.81
For compound 3 the middle estimate is 0.41 log units below the measured one, and the stated range covers the measured number.
By their numbers in this assay, from the lowest: compound 2; then compounds 3 and 1 (each within the scatter of the next).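

With the shared core held constant, the chain on the terminal nitrogen is the one place where a single change can be read. In this assay, ethyl in place of hydroxy on a saturated chain carbon, two bonds along the chain from an amine nitrogen, gives a number 0.71 log units higher from compound 2 to compound 3 (beyond the scatter) and so shows that this position is sensitive to what it carries, which the earlier pair, differing in more than one place, could not show. The change removes one oxygen, with one hydrogen-bond donor and one hydrogen-bond acceptor, and adds two carbons, but nothing available explains the gain or tells which part of this exchange matters.

As far as these compounds go, it remains open whether the number follows the length of the chain or the absence of the hydroxy, a question that a propyl chain, a longer hexyl chain or a methoxy group at this place on the shared core could help to separate. Also open, from the compounds shown here alone, are how an amine or a carboxylic acid at the end of the chain would read, and whether the same change holds on the core of compound 1.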